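Furan to Thiophene Swap on an Inactive Nucleoside Core

The compounds below may be only part of what the source reports. "The series", "measured", "known", "first", "only" and "open" are said of these compounds alone.

Measured compounds:
Compound 1 `Cc1nc(N)c2c(-c3cccs3)cn([C@@H]3O[C@H](CO)[C@@H](O)[C@H]3O)c2n1` gives > 20000 nM.
Compound 2 `Cc1nc(N)c2c(-c3ccco3)cn([C@@H]3O[C@H](CO)[C@@H](O)[C@H]3O)c2n1` gives > 20000 nM.
Compound 3 `Nc1nc2c(c(-c3ccco3)cn2[C@@H]2O[C@H](CO)[C@@H](O)[C@H]2O)c(=O)[nH]1` gives > 20000 nM.

All three values come from a functional assay on HCT-116 cells (Homo sapiens), read by MTT assay, with a stated time of 72 h; a higher number here means a weaker inhibitor, a lower number a stronger inhibitor. Each of them is a limit of the assay rather than a measured number: none of the three compounds reached half-maximal inhibition within the tested range. Compound 2 and compound 1 share one core and differ only by thiophen-2-yl in place of furan-2-yl on an aromatic carbon. The step between them, a step that the two limits leave unreadable from compound 2 to compound 1, cannot be read, since both ends sit at the limit; this is summed up in the limit of > 20000 nM in this assay, at which 3 of the 3 values shown sit.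

Compound 3 carries a different core from compound 2; how the two cores differ is not broken down here. Compound 4 `Nc1nc2c(c(-c3cccs3)cn2[C@@H]2O[C@H](CO)[C@@H](O)[C@H]2O)c(=O)[nH]1` has not yet been tested in this assay. It arises from compound 3 by thiophen-2-yl in place of furan-2-yl on an aromatic carbon, and the surroundings of that change are the same, word for word, as in the change from compound 2 to compound 1, so it is the same change made on the second core.

Within the data shown here, with every measured value at the limit, the only guide for compound 4 is that the same swap on the first core gave no readable step, as the limit of > 20000 nM in this assay, at which 3 of the 3 values shown sit, records. Compound 4 is therefore expected to stay at the limit as well, with an estimated value of 30000 nM, spanning 15000 nM to 100000 nM, which corresponds to an expected step that the limit leaves unreadable from compound 3 to compound 4.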

Compound 4, half-maximal inhibitory concentration: 19800 nM
Compound 4: middle estimate off by 1.5-fold (0.18 log units), on the high side; the range from low to high includes it.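

In this assay compound 3 gives > 20000 nM, which is a limit of the assay and not a number. Thiophen-2-yl in place of furan-2-yl on this core gives a number no higher from compound 3 to compound 4 (the limit leaves the size open), so the change does not raise the number here, but how far it lowers it, if at all, stays unknown. The same change on the other core cannot be read either, so the two steps cannot be set side by side, and the data show neither that the change carries over from one core to the other in size nor that it fails to: the limit of > 20000 nM in this assay, at which 3 of the 4 values shown sit.

As far as these compounds go, it remains open whether a different group on this aromatic carbon, such as a phenyl ring, an amine or a carboxylic acid, would give a clearly lower number on either core. From the compounds shown here alone, it also remains open whether the core of compound 4 differs from the core of compound 1 in any way that a value well clear of the limit could reveal.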